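This account rests on a few compounds, and the source may have more. Where it says the series, first, only, none or still open, it means among the compounds named here.

In a functional assay on SF-295 cells (Homo sapiens) for cytotoxicity, read by sulforhodamine B assay, with a stated time of 48 h (a lower number here means a stronger inhibitor of growth, a higher number a weaker inhibitor of growth), compound 2 `O=C(N/N=c1\scc(-c2ccc(Cl)cc2)n1-c1ccc(Cl)cc1Cl)c1ccc(O)cc1` gives 9770 nM, level with compound 1 `COc1ccc(-c2cs/c(=N\NC(=O)c3ccc(O)cc3)n2-c2ccc(OC)cc2OC)cc1`, which gives 9770 nM; together these are the lowest of the three numbers. Compound 3 `O=C(c1ccc(O)cc1)n1nc(-c2c(Cl)cccc2Cl)sc1=S` gives 29500 nM, a higher number that lies beyond the scatter. Compound 4 `COc1ccc(-n2c(-c3ccc(Cl)cc3)cs/c2=N\NC(=O)c2ccc(O)cc2)c(OC)c1` is not yet measured; it differs from compound 2 by 2,4-dimethoxyphenyl in place of 2,4-dichlorophenyl on an aromatic nitrogen. Among the compounds with values here, no step between measured compounds isolates this change, yet compound 1 carries the same 2,4-dimethoxyphenyl and gives 9770 nM, level with compound 2, so no step beyond the scatter is expected in this assay. Compound 4 is therefore expected at 9770 nM, between 4000 nM and 25000 nM. This change is estimated as a step of no change at the digits printed from compound 2 to compound 4 (within the scatter).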

Compound 4, concentration for total growth inhibition: < 100000 nM
Compound 4: a limit, no number; the forecaster's own chance of this, stated with the estimate: 10%; the middle value is on the limit's open side.
By their numbers in this assay, from the lowest: compounds 1 and 2 (each within the scatter of the next); then compound 3.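

In this assay, within the data shown here, compound 4 gives < 100000 nM, a limit and not a number, so no step from compound 2 or compound 1 to compound 4 can be read. The compounds shown leave open whether 2,4-dimethoxyphenyl in place of 2,4-dichlorophenyl on an aromatic nitrogen changes the number in this assay at all.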